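The source may hold more compounds than are shown below. What is called first, only, known or untested is meant among the compounds shown, and "the series" means these compounds.

Compound 3 `CC(C)=CCCN(C)C1CCN(CCCc2c[nH]c3ccc(-n4cnnc4)cc23)CC1` gives 2.6 nM in an assay on CHO cells for displacement of a labelled ligand from 5-hydroxytryptamine receptor 1D (Homo sapiens) (a lower number here means a stronger inhibitor, a higher number a weaker inhibitor), the second highest of the three numbers; compound 1 `CN(Cc1ccccc1)CC1CCN(CCCc2c[nH]c3ccc(-n4cnnc4)cc23)CC1` gives 0.9 nM and compound 2 `CN(Cc1ccc(S(C)(=O)=O)cc1)C1CCN(CCCc2c[nH]c3ccc(-n4cnnc4)cc23)CC1` gives 18 nM. Compound 4 `CN(Cc1ccco1)C1CCN(CCCc2c[nH]c3ccc(-n4cnnc4)cc23)CC1` differs from compound 3 in one place: furan-2-yl in place of 3-methylbut-2-en-1-yl on a saturated chain carbon bound to an amine nitrogen. Going by the values given here, two measured steps bear on this. The step of a 6.9-fold lower number from compound 2 to compound 3 (0.84 log units; beyond the scatter) shows that an aromatic ring on that chain carbon, there a 4-(methylsulfonyl)phenyl, gave a higher number than the 3-methylbut-2-en-1-yl chain, while a 2.9-fold higher number from compound 1 to compound 3 (0.46 log units; beyond the scatter) shows a (benzyl(methyl)amino)methyl group on a saturated ring carbon giving the lowest number. A furan-2-yl ring is expected to land between these cases, so a modest rise is estimated: a 1.9-fold higher number from compound 3 to compound 4 (0.28 log units; within the scatter). Compound 4 is therefore expected at 5 nM, within 1.5 nM to 15 nM.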

Compound 4, half-maximal inhibitory concentration: 9.3 nM
Estimate against measurement, compound 4: 1.9-fold (0.27 log units) below; measured number inside the range.
By their numbers in this assay, from the lowest: compound 1; then compound 3; then compounds 4 and 2 (each within the scatter of the next).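

In this assay the furan-2-yl ring on a saturated chain carbon bound to an amine nitrogen gives a 3.6-fold higher number from compound 3 to compound 4 (0.55 log units; beyond the scatter) against the 3-methylbut-2-en-1-yl chain, yet a 1.9-fold lower number from compound 2 to compound 4 (0.29 log units; within the scatter) leaves it unseparated from the 4-(methylsulfonyl)phenyl ring, so both aromatic rings part from the open chain in the same direction. The largest new step is a 10-fold higher number from compound 1 to compound 4 (1.01 log units; beyond the scatter) on a saturated ring carbon, where ((furan-2-yl)methyl)(methyl)amino stands in place of (benzyl(methyl)amino)methyl. No supporting measurement explains these steps.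

Going by these compounds, whether a thiophen-2-yl or pyridin-3-yl ring on that chain carbon would stay with these two aromatic rings remains open.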